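An Aryl Ring in Place of a Methyl Group

The compounds below may be only part of what the source reports. "The series", "measured", "known", "first", "only" and "open" are said of these compounds alone.

Compound 1 `Cc1cc(C)c(N2CCN(c3ncccn3)CC2)nn1`: > 100000 nM
Compound 2 `Cc1ccc(-c2cc(C)c(N3CCN(c4ncccn4)CC3)nn2)cc1`: 17200 nM
Compound 3 `Cc1cc(-c2ccsc2)nnc1N1CCN(c2ncccn2)CC1`: 2400 nM

In a functional assay on BV-2 cells (Mus musculus) for inhibition, read by ELISA, with a stated time of 16 h (a higher number here means a weaker inhibitor, a lower number a stronger inhibitor), compound 1 gives > 100000 nM, which is a limit of the assay rather than a number (the limit of > 100000 nM in this assay, at which 1 of the 3 values shown sits). For compound 1 only this limit is known, so it stands at the weak end of the three. Compound 2 gives 17200 nM, and compound 3 gives 2400 nM.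

Compound 4 `Cc1cc(-c2cccnc2)nnc1N1CCN(c2ncccn2)CC1` differs from compound 1 in one place: pyridin-3-yl in place of methyl on an aromatic carbon. Among the compounds with values here, two measured steps bear on this change, since both replace the same methyl group with a ring: an at least 5.8-fold lower number from compound 1 to compound 2 (0.76 log units; beyond the scatter) and an at least 41-fold lower number from compound 1 to compound 3 (1.61 log units; beyond the scatter). Between the two rings themselves, a 7.2-fold lower number from compound 2 to compound 3 (0.86 log units; beyond the scatter). Both ring-for-methyl replacements lowered the number beyond the scatter, so a pyridin-3-yl in place of the methyl is expected to lower the number as well, to a size somewhere between those two steps. Compound 4 is therefore estimated at 8000 nM, within a range of 2000 nM to 40000 nM. The expected step from compound 1 is an at least 12-fold lower number from compound 1 to compound 4 (1.09 log units; beyond the scatter), though only a limit is known for compound 1, so the true size of the step cannot be fixed.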

Compound 4, half-maximal inhibitory concentration: > 100000 nM
Compound 4: no number, only a limit (the forecaster's own chance of this, stated with the estimate: 10%); at least 12-fold (1.09 log units) between middle value and limit.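

In this assay compound 4 gives > 100000 nM and this is a limit of the assay and not a number, the same kind of result as for compound 1: the limit of > 100000 nM in this assay, at which 2 of the 4 values shown sit. With both of these compounds at a limit, the step between them cannot be read, so nothing shows that pyridin-3-yl does any better or worse than the methyl group at this position. What the result adds is that a ring here does not by itself lower the number, since compound 4 goes against the trend seen with compound 2 and compound 3: the change to pyridin-3-yl gives an at least 41-fold higher number from compound 3 to compound 4 (1.61 log units; beyond the scatter) and also an at least 5.8-fold higher number from compound 2 to compound 4 (0.76 log units; beyond the scatter), both beyond the scatter.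

The compounds shown leave open whether the ring nitrogen of pyridin-3-yl is what separates compound 4 from the other two aryl compounds, a question that an unsubstituted phenyl ring at this position would address. They also leave open whether the place of that nitrogen matters, as a comparison with pyridin-4-yl or pyridin-2-yl would show.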